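Adding a methoxy group to compound 2

The compounds below may be only part of what the source reports. "The series", "measured", "known", "first", "only" and "open" are said of these compounds alone.

Compound 1 `Cc1nccn1-c1csc(Nc2cccc(Br)c2)n1` gives > 100000 nM (a limit, not a number)
Compound 2 `Cc1nccn1-c1csc(Nc2ccccc2)n1` gives 32500 nM

Within the data shown here, in a functional assay on RKO cells (Homo sapiens) for cytotoxicity, read by resazurin assay, with a stated time of 72 h (on this read-out lower numbers stand for stronger inhibition and higher numbers for weaker inhibition), compound 2 holds the only exact number so far, 32500 nM, so it is the sole firm reference point. Compound 1 sits at the limit of > 100000 nM in this assay, at which 1 of the 2 values shown sits, and is a limit only.

Compound 3 `COc1cccc(Nc2nc(-n3ccnc3C)cs2)c1` is compound 2 with one change (methoxy in place of hydrogen on an aromatic carbon): methoxy in place of hydrogen on an aromatic carbon, meta to a large group.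

Among the measured compounds shown here, only one measured step bears on this, and it concerns a different group. It is an at least 3.0-fold lower number from compound 1 to compound 2 (0.48 log units; beyond the scatter), seen when hydrogen replaces bromo on an aromatic carbon. Read in reverse, that step suggests that adding a group to this ring may push the number up, though a single pair is thin support for a methoxy. A small upward move is therefore expected, and it may not clear the usual scatter. The estimated change is a 1.7-fold higher number from compound 2 to compound 3 (0.23 log units; within the scatter) in this direction. For compound 3 the expected value is 55000 nM, with an estimated range from 18000 nM to 150000 nM here.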

Compound 3, half-maximal inhibitory concentration: 22500 nM
For compound 3 the middle estimate is 2.4-fold (0.39 log units) above the measured one; the range from low to high includes it.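

Placing methoxy in place of hydrogen on an aromatic carbon, meta to a large group, gives a 1.4-fold lower number from compound 2 to compound 3 (0.16 log units; within the scatter) in this assay, so this place on the ring accepts a methoxy with no change that can be told apart from the scatter. Compound 1 alone might have suggested that any added group here pushes the number up, but swapping bromo for methoxy gives an at least 4.4-fold lower number from compound 1 to compound 3 (0.64 log units; beyond the scatter), so among these compounds the identity of the group matters, not merely the presence of one. The true size of that step stays unknown, since compound 1 is held only at a limit and not at an exact number: the limit of > 100000 nM in this assay, at which 1 of the 3 values shown sits.

The compounds shown leave open whether any group at this place can bring the number clearly below that of compound 2, since a single methoxy and a single bromo are only two samples of what could sit there. An amine, a carboxylic acid or a longer chain such as propoxy could show whether the ring tolerates more than this small ether, and whether bromo or methoxy is the more typical case.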